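The source may hold more compounds than are shown below. What is called first, only, known or untested is meant among the compounds shown, and "the series" means these compounds.

Compound 1 `COc1ccc(C2=C(c3cc(OC)c(OC)c(OC)c3)C(=O)CC2O[SiH2]C(C)(C)C)cc1OC`: in an ADME assay on HT-29 cells (Homo sapiens) for cytotoxicity, read by MTT assay, with a stated time of 72 h (on this read-out higher numbers stand for weaker inhibition and lower numbers for stronger inhibition), compound 1 gives > 100 ug/mL, a limit of the assay. Compound 2 `COc1ccc(C2=C(c3cc(OC)c(OC)c(OC)c3)C(=O)C(O)C2)cc1NC(=O)c1ccccc1`: in this assay compound 2 gives > 100 ug/mL, again a limit. Compound 3 `COc1ccc(C2=C(c3cc(OC)c(OC)c(OC)c3)C(=O)C(OC(C)=O)C2)cc1OC(C)C`: in this assay compound 3 gives > 100 ug/mL, also a limit.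

Compound 1 therefore stands where the other two measured compounds stand, at the limit of > 100 ug/mL in this assay, at which 3 of the 3 values shown sit, and none of the three yields a number. Compound 4 `COc1cc(C2=C(c3ccccc3)C(O[SiH2]C(C)(C)C)CC2=O)cc(OC)c1OC` differs from compound 1 in one place: phenyl in place of 3,4-dimethoxyphenyl on a double-bonded ring carbon. Among the compounds with values here, no measured step matches this change, so its direction is open. Given that compound 1 sits at the limit of > 100 ug/mL in this assay, at which 3 of the 3 values shown sit, compound 4 is expected to remain near that limit, with a step of a number no higher from compound 1 to compound 4 (the limit leaves the size open) not beyond the scatter. Compound 4 is thus estimated at 100 ug/mL, between 25 ug/mL and 400 ug/mL, and a limit rather than a number is the likelier outcome.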

Compound 4, half-maximal inhibitory concentration: > 100 ug/mL
Compound 4: no number, only a limit; the forecaster's own chance of this, stated with the estimate: 70%; the middle value sits exactly at the limit.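

Compound 1 and compound 4 both sit at a limit, so no step can be read from one to the other: the limit of > 100 ug/mL in this assay, at which 4 of the 4 values shown sit.

The compounds shown leave open whether any change to the shared core gives a measurable half-maximal inhibitory concentration in this assay.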